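A few compounds are considered here, and "the series" means these few. Any claim that something is new, unique, unknown or untested is made for them only; others in the source may bear on it.

Measured so far in an assay on Sf21 cells for inhibition of high affinity nerve growth factor receptor (Homo sapiens), read by HTRF, with a stated time of 30 min, in the presence of a further agent that is not named here; on this read-out higher numbers stand for weaker inhibition and lower numbers for stronger inhibition:
- compound 1, `COc1cccc(CN2Cc3c(NC(=O)c4ccccc4)n[nH]c3C2(C)C)c1`, gives 1120 nM
- compound 2, `CC1(C)c2[nH]nc(NC(=O)c3ccccc3)c2CN1Cc1cccc(F)c1F`, gives 200 nM
- compound 3, `CC1(C)c2[nH]nc(NC(=O)c3ccccc3)c2CN1Cc1cc(F)ccc1F`, gives 480 nM

All three share one core and differ only in the aromatic group on the saturated chain carbon bound to the amine nitrogen in the ring. Within this set compound 3 stands second highest of the three numbers: its nearest neighbour is compound 1, as a 2.3-fold lower number from compound 1 to compound 3 (0.37 log units; beyond the scatter) shows, and its furthest is compound 2, as a 2.4-fold higher number from compound 2 to compound 3 (0.38 log units; beyond the scatter) shows. The widest step observed is a 5.6-fold lower number from compound 1 to compound 2 (0.75 log units; beyond the scatter).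

The next compound, compound 4, `CC1(C)c2[nH]nc(NC(=O)c3ccccc3)c2CN1Cc1ccc(F)c(F)c1`, is not yet measured. It carries the change (3,4-difluorophenyl in place of 2,5-difluorophenyl on a saturated chain carbon bound to an amine nitrogen in a ring). Going by the values given here, no measured step places fluorines in exactly this way, so only the steps among the difluoro and methoxy analogues bear on it. The step of a 2.4-fold higher number from compound 2 to compound 3 (0.38 log units; beyond the scatter) shows that shifting two fluorines around the same ring moves this assay by a modest amount and in either direction, while a 5.6-fold lower number from compound 1 to compound 2 (0.75 log units; beyond the scatter) and a 2.3-fold lower number from compound 1 to compound 3 (0.37 log units; beyond the scatter) show that both difluoro patterns sit below the methoxy compound. For compound 4 a step near zero or modest in either direction is therefore expected, a 1.0-fold higher number from compound 3 to compound 4 (0.02 log units; within the scatter), with the number estimated at 500 nM, in the range 150 nM to 1500 nM.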

Compound 4, half-maximal inhibitory concentration: 680 nM
The estimate for compound 4 lay 1.4-fold (0.13 log units) below the measured number; the range from low to high includes it.
By their numbers in this assay, from the lowest: compound 2; then compounds 3, 4 and 1 (each within the scatter of the next, the first and the last beyond it).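

In this assay, the 3,4-difluorophenyl group cannot be told apart from the 2,5-difluorophenyl group (a 1.4-fold higher number from compound 3 to compound 4 (0.15 log units; within the scatter)) or from the 3-methoxyphenyl group (a 1.6-fold lower number from compound 1 to compound 4 (0.22 log units; within the scatter)), so the earlier separation of both difluoro patterns from the methoxy compound does not extend to this third pattern. The 2,3-difluorophenyl group remains clearly apart (a 3.4-fold higher number from compound 2 to compound 4 (0.53 log units; beyond the scatter)), and with its steps to the other three all beyond the scatter, compound 2, at 200 nM, is the most potent of the four, so at this position the placement of the two fluorines matters, not just their presence. No measurement bears on why this placement separates the compounds.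

Open, from the compounds shown here alone, is how an unsubstituted phenyl group or a single fluorine on the phenyl ring would compare with the 2,3-difluorophenyl group, which would show whether one fluorine or the pair accounts for the standing of compound 2. Also open, going by these compounds, is whether 2,3-dichlorophenyl or a pyridyl ring, placed on the same saturated chain carbon bound to the amine nitrogen in the ring, would hold that level.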